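Swapping a Cyclopentyl for an Isopropoxy on the Amide Carbonyl

The source may hold more compounds than are shown below. What is called first, only, known or untested is meant among the compounds shown, and "the series" means these compounds.

Measured so far in an assay on CHO-K1 cells for displacement of a labelled ligand from prostaglandin E2 receptor EP1 subtype (Homo sapiens); on this read-out lower numbers stand for stronger inhibition and higher numbers for weaker inhibition:
compound 1, `Cc1cc(C(=O)NN2CCCCC2)nn1Cc1cc(Cl)ccc1OCC(C)C`, gives 200 nM;
compound 2, `Cc1cc(NC(=O)C2CCCC2)nn1Cc1cc(Cl)ccc1OCC(C)C`, gives 25.1 nM.

Among these two numbers compound 2 stands lowest; the nearest is compound 1, and the step of an 8.0-fold lower number from compound 1 to compound 2 (0.90 log units; beyond the scatter) is larger than the usual scatter. Compound 3, `Cc1cc(NC(=O)OC(C)C)nn1Cc1cc(Cl)ccc1OCC(C)C`, has not yet been measured. It differs from compound 2 by isopropoxy in place of cyclopentyl on a carbonyl carbon. Going by the values given here, the only measured step, from compound 1 to compound 2, alters the same amide-bearing region but through a different change, so it does not bear directly on this one; it shows only that changes in this part of the molecule can shift the number in this assay considerably. With no closer guide, a step of modest size toward a higher number is expected for compound 3, a 2.4-fold higher number from compound 2 to compound 3 (0.38 log units; beyond the scatter). Compound 3 is therefore estimated at 60 nM, within a range of 15 nM to 250 nM.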

Compound 3, half-maximal inhibitory concentration: 50.1 nM
Compound 3: the middle estimate sits 1.2-fold (0.08 log units) above what was measured; the measured number falls inside the stated range.
By their numbers in this assay, from the lowest: compounds 2 and 3 (each within the scatter of the next); then compound 1.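

Placing isopropoxy on the carbonyl carbon instead of cyclopentyl gives a 2.0-fold higher number from compound 2 to compound 3 (0.30 log units; within the scatter) in this assay, so an open group containing oxygen serves here as well as a five-membered carbon ring, and this assay does not separate the two. The change from (piperidin-1-yl)carbamoyl to (isopropoxycarbonyl)amino gives a 4.0-fold lower number from compound 1 to compound 3 (0.60 log units; beyond the scatter) and goes the same way as the step to compound 2, so among these compounds the gain over compound 1 does not depend on the cyclopentyl ring. No measurement available here explains why these two groups give such similar results.

Going by these compounds, it remains open how far this carbonyl carbon accepts other groups, such as a dimethylamino group or a longer chain like n-butoxy. On these data alone, whether any of them would move the number beyond the scatter in either direction also remains unknown.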